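A few compounds are considered here, and "the series" means these few. Any claim that something is new, unique, unknown or untested is made for them only; others in the source may bear on it.

Measured compounds:
- compound 1, `N/C(=N\NC(=S)N1CCCC1)c1ccc(F)cn1`: 1000 nM
- compound 2, `N/C(=N\NC(=S)N1CCSCC1)c1ccccn1`: 6700 nM
- compound 3, `N/C(=N\NC(=S)N1CCCCC1)c1ccccn1`: 6900 nM

In a functional assay on A-431 cells (Homo sapiens) for cytotoxicity, read by MTT assay, with a stated time of 72 h (a lower number here means a stronger inhibitor, a higher number a weaker inhibitor), compound 2 gives 6700 nM, the second highest of the three numbers. Compound 3 sits next to it, and the step of a 1.0-fold higher number from compound 2 to compound 3 (0.01 log units; within the scatter) shows that exchanging one saturated ring for the other on the thiocarbonyl carbon leaves the number essentially unchanged. Compound 1 stands furthest away with 1000 nM, but it differs from both compound 2 and compound 3 in two places, so its lower number cannot be assigned to either change on its own.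

Compound 4, `N/C(=N\NC(=S)N1CCSCC1)c1ccc(F)cn1`, is obtained from compound 2 by fluoro in place of hydrogen on an aromatic carbon. Going by the values given here, no measured step tests this change by itself. Among the compounds with values here, the only step available, from compound 2 to compound 3, concerns the other end of the molecule and was within the scatter; it tells nothing direct about the fluoro. Within the data shown here, compound 1, the one fluorinated compound measured, does carry the lowest number, which is the sole hint in this assay. On that basis compound 4 is expected to move modestly downward, with a step of a 3.4-fold lower number from compound 2 to compound 4 (0.53 log units; beyond the scatter), giving an estimate of 2000 nM, within a range from 700 nM to 6000 nM.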

Compound 4, half-maximal inhibitory concentration: 1200 nM
Compound 4: middle estimate off by 1.7-fold (0.22 log units), on the high side; the measured number falls inside the stated range.
By their numbers in this assay, from the lowest: compounds 1 and 4 (each within the scatter of the next); then compounds 2 and 3 (each within the scatter of the next).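

In this assay, the fluoro group on the aromatic carbon two atoms from the ring nitrogen is now tested as a single change, which compound 1 could not do, and replacing hydrogen there gives a 5.6-fold lower number from compound 2 to compound 4 (0.75 log units; beyond the scatter). With fluoro present, thiomorpholin-4-yl in place of pyrrolidin-1-yl gives a 1.2-fold higher number from compound 1 to compound 4 (0.08 log units; within the scatter), so the lower number of compound 1 follows the fluoro rather than the pyrrolidin-1-yl ring. No measurement shown here accounts for the effect of the fluoro group.

On these data alone, whether a chloro group, a methoxy group or an amine on this same aromatic carbon would give a similar number remains open. As far as these compounds go, it is also open whether fluoro has the same effect when compound 3, with its piperidin-1-yl ring, is the starting point.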